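Acid to amide: from compound 2 toward compound 4

A few compounds are considered here, and "the series" means these few. Any claim that something is new, unique, unknown or untested is made for them only; others in the source may bear on it.

Measured so far:
compound 1, `CCc1ccccc1C(=O)Nc1c[nH]nc1C(=O)N[C@H]1CC[C@H](OC)CC1`, 3400 nM
compound 2, `COc1cccc(OC)c1C(=O)Nc1c[nH]nc1C(=O)O`, > 50000 nM
compound 3, `CO[C@H]1CC[C@H](NC(=O)c2n[nH]cc2NC(=O)c2ccccc2C(F)(F)F)CC1`, 3300 nM

In an ADME assay on MRC5 cells (Homo sapiens) for inhibition, with a stated time of 72 h (a lower number here means that less compound is needed, a higher number that more compound is needed for the effect), compound 1 gives 3400 nM. Compound 3 gives 3300 nM in this assay, and the step of a 1.0-fold lower number from compound 1 to compound 3 (0.01 log units; within the scatter) lies within the scatter. Compound 2 is different: in this assay compound 2 gives only a limit, > 50000 nM, and no number; it sits at the limit of > 50000 nM in this assay, at which 1 of the 3 values shown sits, alone among the three.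

The step to compound 4, `COc1cccc(OC)c1C(=O)Nc1c[nH]nc1C(=O)NCc1ncccc1C`, changes compound 2 at the carbonyl carbon: ((3-methylpyridin-2-yl)methyl)amino in place of hydroxy on a carbonyl carbon. Going by the values given here, no measured step touches this position; the only measured step, from compound 1 to compound 3, concerns a substituent on an aromatic carbon and says nothing about the carbonyl. Compound 1 and compound 3 do show that the shared core, carrying an amide at this carbonyl, gives numbers rather than limits, while compound 2 with hydroxy there gives a limit. Compound 4 is therefore expected to move off the limit, with a step estimated at an at least 6.2-fold lower number from compound 2 to compound 4 (0.79 log units; beyond the scatter), though with wide uncertainty. For compound 4 the estimate in this assay is 8000 nM, between 2000 nM and 50000 nM.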

Compound 4, half-maximal effective concentration: > 50000 nM
Compound 4 was reported as a limit; the forecaster's own chance of this, stated with the estimate: 30%; at least 6.2-fold (0.79 log units) between middle value and limit.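

Compound 2 and compound 4 are both reported as limits and not as numbers in this assay and the step between them cannot be read: the limit of > 50000 nM in this assay, at which 2 of the 4 values shown sit.

In this assay the compounds shown leave open whether ((3-methylpyridin-2-yl)methyl)amino in place of hydroxy on this carbonyl carbon changes the result at all.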